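This account rests on a few compounds, and the source may have more. Where it says the series, first, only, none or still open, it means among the compounds named here.

Compound 1 `COC(=O)c1c([N+](=O)[O-])noc1-c1ccccc1Cl`: 80100 nM
Compound 2 `O=C(O)c1c([N+](=O)[O-])noc1-c1ccc([N+](=O)[O-])cc1`: "not determined" (no result reported)

In an ADME assay on J774.A1 cells (Mus musculus) for cytotoxicity, read by MTT assay, with a stated time of 48 h (a lower number here means that less compound is tolerated, a higher number that more compound is tolerated), compound 1 gives 80100 nM. For compound 2, which carries a carboxy group on the shared core, this assay reports no result, so compound 2 stands without a single number against which a step could be read. Compound 3 `CC(C)CCNC(=O)c1c([N+](=O)[O-])noc1-c1ccc([N+](=O)[O-])cc1` is the next compound to be tested in this assay. It differs from compound 2 by the change (isopentylamino in place of hydroxy on a carbonyl carbon), that is, isopentylamino in place of hydroxy on a carbonyl carbon. For the measured compounds named here, since no step from compound 2 is known, the expectation for compound 3 rests on compound 1, the only compound with a number in this assay, and a moderate shift toward less compound being tolerated, beyond the usual scatter, is expected for compound 3. The concentration for compound 3 in this assay is estimated at 40000 nM, within a range of 10000 nM to 150000 nM.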

Compound 3, half-maximal cytotoxic concentration: 67000 nM
Estimate against measurement, compound 3: 1.7-fold (0.22 log units) below; the measured number falls inside the stated range.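

For the compounds shown here, compound 2 stands without a single number in this assay, and no step to compound 3 can be read. Going by these compounds, what the change from carboxy to isopentylcarbamoyl does to the tolerated concentration stays open. No evidence shown here bears on this result.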